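A few compounds are considered here, and "the series" means these few. Any claim that something is new, unique, unknown or untested is made for them only; others in the source may bear on it.

Compounds built on one shared core can be compared by asking how far a single change in structure moves a measurement, here a toxicity assay on J774.A1 cells (Mus musculus) for cytotoxicity, read by SYBR Green assay, with a stated time of 1 h; a higher number here means that more compound is needed for the effect, a lower number that less compound is needed. In this test compound 1 `CN(C)c1ccc2cc(-c3ccccc3Br)c(N)nc2c1` gives 12000 nM, and compound 2 `Cc1ccccc1-c1cc2ccc(N(C)C)cc2nc1N` gives 6800 nM. These two compounds differ by methyl in place of bromo on an aromatic carbon, and the result is a 1.8-fold lower number from compound 1 to compound 2 (0.25 log units; within the scatter). Compound 3 `CN(C)c1ccc2cc(-c3nccn3C)c(N)nc2c1` offers no number to start from, as its entry reads "not determined" (no result reported).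

Compound 4 `CN(C)c1ccc2cc(-c3ncccc3F)c(N)nc2c1` differs from compound 3 in one place: 3-fluoropyridin-2-yl in place of 1-methyl-1H-imidazol-2-yl on an aromatic carbon. In words, this is 3-fluoropyridin-2-yl in place of 1-methyl-1H-imidazol-2-yl on an aromatic carbon, ortho to an amino group.

Among the compounds with values here, no measured step covers this exchange, and the only one available, a 1.8-fold lower number from compound 1 to compound 2 (0.25 log units; within the scatter), concerns different groups, so it bears on the change only indirectly. With no value for compound 3, a step from it cannot be sized or given a direction. The best guide is the region set by compound 1 at 12000 nM and compound 2 at 6800 nM, and nothing beyond the scatter from that region is expected in this assay. The range is kept wide since neither of those compounds carries the new group. The expected value for compound 4 is 9000 nM, with an estimated range from 3000 nM to 27000 nM.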

Compound 4, half-maximal effective concentration: 16000 nM
Estimate against measurement, compound 4: 1.8-fold (0.25 log units) below, within the range that was stated.
By their numbers in this assay, from the lowest: compounds 2, 1 and 4 (each within the scatter of the next, the first and the last beyond it).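

Within the data shown here, at this position in the shared core, compound 4 is the first compound with a number that carries a six-membered aromatic ring with a ring nitrogen and a fluorine, and in this assay the exchange for 2-bromophenyl gives a 1.3-fold higher number from compound 1 to compound 4 (0.12 log units; within the scatter), so these two cannot be told apart. Among these compounds, the exchange for 2-methylphenyl gives a 2.4-fold higher number from compound 2 to compound 4 (0.37 log units; beyond the scatter), which makes this the first step to pass beyond the usual scatter, although only modestly, and it shows that a ring nitrogen and a fluorine can be carried here without a large shift in this read-out. The step from compound 3 to compound 4 cannot be read, as compound 3 has no number, and no measurement shown explains any of these differences.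

Because 3-fluoropyridin-2-yl changes the ring and adds fluorine at once, these compounds cannot separate the part played by the ring nitrogen from that of the fluorine. They also leave open how this assay would respond to a plain phenyl ring, or to a ring bearing an amine or a carboxylic acid.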